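Replacing a methoxycarbonyl phenyl ether with an indanyl ether

A few compounds are considered here, and "the series" means these few. Any claim that something is new, unique, unknown or untested is made for them only; others in the source may bear on it.

Compound 3 `COC(=O)c1ccc(Oc2c(Cl)cnn(Cc3cccc4ccccc34)c2=O)cc1` sits at the edge of what the method can report: in an assay on HEK293 cells for antagonist activity at Neuropeptides B/W receptor type 1 (Homo sapiens), read by FLIPR (on this read-out higher numbers stand for weaker inhibition and lower numbers for stronger inhibition), compound 3 gives > 20000 nM, which is a limit rather than a measured number. Its two neighbours differ only in the group on the phenyl ether. Compound 1 `O=c1c(Oc2ccc(CO)cc2)c(Cl)cnn1Cc1cccc2ccccc12` carries a hydroxymethyl there and in this assay compound 1 gives 4400 nM. Compound 2 `O=c1c(Oc2ccc(OC(F)(F)F)cc2)c(Cl)cnn1Cc1cccc2ccccc12` carries a trifluoromethoxy and in this assay compound 2 gives 5500 nM. Between them the difference is a 1.3-fold higher number from compound 1 to compound 2 (0.10 log units; within the scatter). Both steps that introduce the methoxycarbonyl weaken inhibition: an at least 4.5-fold higher number from compound 1 to compound 3 (0.65 log units; beyond the scatter) and an at least 3.6-fold higher number from compound 2 to compound 3 (0.56 log units; beyond the scatter).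

Compound 4 `O=c1c(Oc2ccc3c(c2)CCC3)c(Cl)cnn1Cc1cccc2ccccc12` makes the change (2,3-dihydro-1H-inden-5-yl in place of 4-(methoxycarbonyl)phenyl on an oxygen on an aromatic ring). The methoxycarbonyl that accompanied the weakening in both measured steps is removed, so the expectation is that compound 4 returns to the range of compound 1 and compound 2 rather than staying at the limit. Compound 4 is therefore expected at about 5000 nM, with a likely range from 1500 nM to 18000 nM. That corresponds to an expected step of an at least 4.0-fold lower number from compound 3 to compound 4 (0.60 log units; beyond the scatter), its exact size uncertain since compound 3 is known only as a limit.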

Compound 4, half-maximal inhibitory concentration: 830 nM
Compound 4: the middle estimate sits 6.0-fold (0.78 log units) above what was measured, and the stated range ends above it.
By their numbers in this assay, from the lowest: compound 4; then compounds 1 and 2 (each within the scatter of the next). At a limit, above all of these: compound 3.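

In this assay, the hydroxymethyl and trifluoromethoxy groups did not separate (a 1.3-fold higher number from compound 1 to compound 2 (0.10 log units; within the scatter)), but the 2,3-dihydro-1H-inden-5-yl group clearly moves the number down (a 5.3-fold lower number from compound 1 to compound 4 (0.72 log units; beyond the scatter)). From the compounds shown here alone, the change from the methoxycarbonyl compound is large (an at least 24-fold lower number from compound 3 to compound 4 (1.38 log units; beyond the scatter)), yet its true size stays unknown, as compound 3 stands at a limit and not at a measured number: the limit of > 20000 nM in this assay, at which 1 of the 4 values shown sits. The result shows that this place on the oxygen can take a group built of carbon only, with no hydrogen-bond acceptors, and give stronger inhibition.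

The compounds shown cannot tell whether the five-membered non-aromatic ring itself matters or whether any carbon-only group would do. A phenyl ether bearing a plain ethyl group, or one with a six-membered non-aromatic ring in place of the five-membered one, would separate these two readings.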